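The source may hold more compounds than are shown below. What is called first, only, known or untested is meant among the compounds shown, and "the series" means these compounds.

Two compounds share one core, and both have been tested in a functional assay on CHO cells with adenosine receptor A1 (Homo sapiens) as the target, read by cAMP accumulation and immunoassay, with a stated time of 6 min, tested at 0.1 uM; a lower number here means a stronger effect, a higher number a weaker effect of the compound at the concentration tested. Compound 1, `Nc1scc(CN2CCN(c3cccc(Cl)c3Cl)CC2)c1C(=O)c1ccc(Cl)cc1`, gives 3.2% in this assay. Compound 2, `Nc1scc(CN2CCN(C3CCCCCC3)CC2)c1C(=O)c1ccc(Cl)cc1`, gives 13% in this assay; of the two numbers measured, compound 2 stands at that value, and its gap to compound 1 is within the scatter. Going by the values given here, the one measured step joins these two: a number 9.8 percentage points higher from compound 1 to compound 2 (within the scatter). It tells that swapping an aromatic ring for a saturated seven-membered ring on that nitrogen changed the read-out by no more than the noise.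

Compound 3, `Nc1scc(CN2CCN(c3ccc(F)c(Cl)c3)CC2)c1C(=O)c1ccc(Cl)cc1`, has not yet been measured. It differs from compound 2 at the same place, (3-chloro-4-fluorophenyl in place of cycloheptyl on an amine nitrogen in a ring), so it carries an aromatic ring on that nitrogen again, as compound 1 does. Among the compounds with values here, the only step that bears on this is the one from compound 1 to compound 2, which stayed within the scatter, so the step of a number 6 percentage points lower from compound 2 to compound 3 (within the scatter) is expected to be small as well, landing near the values of the two measured compounds. On that basis compound 3 is estimated to give 7% in this assay, within a range from 0% to 20%.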

Compound 3, a percentage reported as activity, at one concentration (the size of the read-out at that concentration, not a potency): -21%
Compound 3: the middle estimate sits 28 percentage points above what was measured, and the stated range ends above it.
By their numbers in this assay, from the lowest: compound 3; then compounds 1 and 2 (each within the scatter of the next).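

In this assay, the group on the amine nitrogen of the shared core can move the read-out well beyond the scatter, as the change to 3-chloro-4-fluorophenyl gives a number 34 percentage points lower from compound 2 to compound 3 (beyond the scatter), and compound 3 gives -21%. An aromatic ring on that nitrogen is not enough to account for this: compound 1 carries one too, yet the exchange of its 2,3-dichlorophenyl for 3-chloro-4-fluorophenyl gives a number 24.2 percentage points lower from compound 1 to compound 3 (beyond the scatter), so these two halogen-bearing phenyl groups are not interchangeable at this position. No measurement at hand explains why the read-out responds to this change.

Still open is which part of the 3-chloro-4-fluorophenyl group matters, the chlorine, the fluorine or the two together, as neither a plain phenyl, a 3-chlorophenyl nor a 4-fluorophenyl group stands among the compounds shown. Also open, going by these compounds, is whether the step would hold with another group in place of the 4-chlorophenyl on the carbonyl, and how it would look as a potency, as each read-out comes from a single concentration.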